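This account rests on a few compounds, and the source may have more. Where it says the series, first, only, none or still open, it means among the compounds named here.

In a functional assay on MDA-MB-231 cells (Homo sapiens) for cytotoxicity, read by MTT assay, with a stated time of 24 h (a lower number here means a stronger inhibitor, a higher number a weaker inhibitor), compound 1 (`Cc1ccc(-c2nnc(CNC(=O)[C@@H](C)N)o2)cc1`) gives 254 nM, compound 2 (`COc1ccc(-c2nnc(CNC(=O)CN)o2)cc1`) gives 276 nM and compound 3 (`COc1ccc(-c2nnc(CNC(=O)[C@@H](C)N)o2)cc1`) gives 295 nM. Compound 3 therefore stands level with the other two, with all three values within the scatter of one another.

The next structure is compound 4 (`C[C@@H](N)C(=O)NCc1nnc(-c2ccc([N+](=O)[O-])cc2)o1`), which differs from compound 3 as follows: nitro in place of methoxy on an aromatic carbon. In words, this is nitro in place of methoxy on an aromatic carbon.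

The measured step closest in kind is a 1.2-fold higher number from compound 1 to compound 3 (0.06 log units; within the scatter), with methoxy in place of methyl on an aromatic carbon. The other measured step, on the saturated chain carbon, is a 1.1-fold higher number from compound 2 to compound 3 (0.03 log units; within the scatter). Both lie within the scatter, but neither involves a nitro group, so the data do not test this change directly.

No step beyond the scatter is expected in this assay, and the expected step is a 1.1-fold lower number from compound 3 to compound 4 (0.02 log units; within the scatter). With nitro untested, the range is kept wide. For compound 4 the estimated value is 280 nM, with an expected range of 120 nM to 650 nM.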

Compound 4, half-maximal inhibitory concentration: 261 nM
Estimate against measurement, compound 4: 1.1-fold (0.03 log units) above; the range from low to high includes it.
By their numbers in this assay, from the lowest: compounds 1, 4, 2 and 3 (each within the scatter of the next).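

Nitro now joins methyl and methoxy on this aromatic carbon, para to a large group, and in this assay the change from methoxy gives a 1.1-fold lower number from compound 3 to compound 4 (0.05 log units; within the scatter) while the change from methyl gives a 1.0-fold higher number from compound 1 to compound 4 (0.01 log units; within the scatter), both within the scatter. The earlier compounds shown here compared only methyl and methoxy here, so the flat reading now extends to a group with a double bond outside aromatic rings and to three different groups across compounds 1, 3 and 4. Nothing measured here accounts for this flat reading.

From the compounds shown here alone, whether an amine, a carboxylic acid or a chlorine on this aromatic carbon would also stay within the scatter remains open. Also open, going by these compounds, is whether a longer chain in place of the methyl on the saturated chain carbon would leave the value of compound 4 unchanged.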